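Series notes: terminal substituent on the biphenyl of compound 3

The source may report more compounds than this note shows. Statements on the series, on what has been measured and on what is new or still open speak of the compounds shown alone.

Going by the values given here, compound 3 `CC[C@H](C)[C@H](N)CN(C(=O)[C@@H]1C[C@H]1c1ccccc1)c1ccc(-c2ccc(OC(C)C)cc2)cc1` stands lowest of the three numbers so far: in a functional assay for agonist activity at G protein-coupled receptor 88 (Homo sapiens), read by HTRF and cAMP accumulation (on this read-out higher numbers stand for an effect only at larger amounts of compound and lower numbers for an effect already at smaller amounts), compound 3 gives 72 nM. Compound 2 `CC[C@H](C)[C@H](N)CN(C(=O)[C@@H]1C[C@H]1c1nc(C)c(C)s1)c1ccc(-c2ccccc2)cc1` gives 3600 nM in this assay and compound 1 `CC[C@H](C)[C@H](N)CN(C(=O)[C@@H]1C[C@H]1c1c(F)cccc1F)c1ccc(-c2ccccc2)cc1` gives 11000 nM, both beyond the scatter away from compound 3. Among the compounds with values here, the one single-point step recorded, a 3.1-fold lower number from compound 1 to compound 2 (0.49 log units; beyond the scatter), concerns 4,5-dimethyl-1,3-thiazol-2-yl in place of 2,6-difluorophenyl on a saturated ring carbon, a different position from the one now in question.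

Compound 4 `CC[C@H](C)[C@H](N)CN(C(=O)[C@@H]1C[C@H]1c1ccccc1)c1ccc(-c2ccc(CO)cc2)cc1` differs from compound 3 by hydroxymethyl in place of isopropoxy on an aromatic carbon, para to a large group. Within the data shown here, no measured step touches this aromatic carbon, and compounds 1 and 2 differ from compound 3 at two places at once, so they give no clean read on it either. With nothing to anchor the step, the expectation for compound 4 is a modest weakening, expected as a 4.2-fold higher number from compound 3 to compound 4 (0.62 log units; beyond the scatter), with wide uncertainty in either direction. Compound 4 is therefore estimated at 300 nM in this assay, expected to fall between 60 nM and 1500 nM.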

Compound 4, half-maximal effective concentration: 1100 nM
Beside the measured number, compound 4's estimate is 3.7-fold (0.56 log units) below it, and the stated range covers the measured number.
By their numbers in this assay, from the lowest: compound 3; then compound 4; then compound 2; then compound 1.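

In this assay, the step of a 15-fold higher number from compound 3 to compound 4 (1.18 log units; beyond the scatter) gives the first clean read on this aromatic carbon, para to a large group, and shows that the substituent here can by itself shift the number by a large margin. The change is not a single-variable one: hydroxymethyl has fewer heavy atoms than isopropoxy and also brings a hydrogen-bond donor that isopropoxy lacks, so this one step cannot separate the two differences. Nothing available explains the direction or size of the step.

The compounds shown leave open whether the higher number for compound 4 follows the shorter group or the hydroxyl, a question that a methoxy or ethoxy group, which has no hydroxyl, or a longer hydroxyalkyl chain such as 2-hydroxyethyl, would help to answer. On these data alone, it also remains open how an amine or a carboxylic acid would read at this carbon, and whether the step would hold in compounds carrying 2,6-difluorophenyl or 4,5-dimethyl-1,3-thiazol-2-yl on the saturated ring carbon.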